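Aryl amide replaced by a dimethylaminopropyl amide

A few compounds are considered here, and "the series" means these few. Any claim that something is new, unique, unknown or untested is made for them only; others in the source may bear on it.

Measured compounds:
compound 1 `Cc1ccccc1NC(=O)CCC(=O)OCCCCCCSc1ccc([N+](=O)[O-])c2nonc12` 440 nM
compound 2 `O=C(CCC(=O)OCCCCCCSc1ccc([N+](=O)[O-])c2nonc12)Nc1ccc(C(F)(F)F)cc1` 90 nM

In an assay on isolated protein for inhibition of glutathione S-transferase Mu 2 (Homo sapiens), with a stated time of 10 min (on this read-out higher numbers stand for weaker inhibition and lower numbers for stronger inhibition), compound 2 stands lowest of the two, with compound 1 giving the higher number. Compound 3 `CN(C)CCCNC(=O)CCC(=O)OCCCCCCSc1ccc([N+](=O)[O-])c2nonc12` differs from compound 2 by 3-(dimethylamino)propyl in place of 4-(trifluoromethyl)phenyl on an amide-type nitrogen. Among the compounds with values here, the only step at this position, a 4.9-fold lower number from compound 1 to compound 2 (0.69 log units; beyond the scatter), exchanged one aryl group for another, so it bears on the new change only loosely, and no step swaps an aryl group for a chain. The direction is therefore open, leaning towards a higher number. Compound 3 is expected to give 600 nM, within 150 nM to 3000 nM, a step of a 6.7-fold higher number from compound 2 to compound 3 (0.82 log units; beyond the scatter).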

Compound 3, half-maximal inhibitory concentration: 90 nM
For compound 3 the middle estimate is 6.7-fold (0.82 log units) above the measured one, outside the stated range (below it).
By their numbers in this assay, from the lowest: compounds 2 and 3 (each within the scatter of the next); then compound 1.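

In this assay, the amide-type nitrogen took a chain with no ring as well as it took an aryl group: 3-(dimethylamino)propyl in place of 4-(trifluoromethyl)phenyl gave no change at the digits printed from compound 2 to compound 3 (within the scatter) here. In place of 2-methylphenyl, the same chain gave a 4.9-fold lower number from compound 1 to compound 3 (0.69 log units; beyond the scatter) at this nitrogen, so among these compounds an aromatic ring on it is not required for the lower number. Nothing measured here explains this result. Going by these compounds, whether a primary amine, a carboxylic acid or a longer chain on this nitrogen would keep that number remains open.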